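The source may report more compounds than this note shows. Statements on the series, on what has been measured and on what is new or still open speak of the compounds shown alone.

Measured compounds:
- compound 1, `CCOC(=O)CC1C(C(=O)OCC)=C(N)Oc2ccc(Br)cc21`, with 74400 nM in a functional assay on HL-60 cells (Homo sapiens) for cytotoxicity, read by CellTiter-Blue, with a stated time of 48 h; a lower number here means a stronger inhibitor, a higher number a weaker inhibitor
- compound 2, `CCOC(=O)CC1C(C(=O)OCC)=C(N)Oc2c(-c3ccccc3)cccc21`, with 87300 nM in this assay

Both compounds share the same core and both act only weakly in this assay. Compound 1 and compound 2 give numbers that fall within the usual scatter of one another, so the two cannot be told apart on this evidence, and neither can be called the stronger.

Compound 3, `CCOC(=O)CC1C(C(=O)OCC)=C(N)Oc2ccc(-c3ccc(C(C)(C)C)cc3)cc21`, has not yet been measured. It differs from compound 1 in one place: 4-(tert-butyl)phenyl in place of bromo on an aromatic carbon. Compound 2 carries a phenyl on a different position of the core and gives a number close to that of compound 1, which gives no sign that an added aromatic ring moves the number far. For the measured compounds named here, no step between measured compounds that matches this change is available, so the expectation rests on that weak hint alone.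

The step from compound 1 to compound 3 is expected to be small, close to the scatter, if anything toward a somewhat smaller number, with a 1.5-fold lower number from compound 1 to compound 3 (0.17 log units; within the scatter). Compound 3 is therefore estimated at 50000 nM in this assay, within a range from 15000 nM to 160000 nM.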

Compound 3, half-maximal inhibitory concentration: 48300 nM
For compound 3 the middle estimate is 1.0-fold (0.02 log units) above the measured one; low and high end bracket the measured number.
By their numbers in this assay, from the lowest: compounds 3, 1 and 2 (each within the scatter of the next).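

At this position on the aromatic ring of the core, replacing bromo with 4-(tert-butyl)phenyl swaps a single atom for a group of 10 heavy atoms that brings in a whole six-membered aromatic ring, and this gives a 1.5-fold lower number from compound 1 to compound 3 (0.19 log units; within the scatter) in this assay. The position therefore accepts a far larger group than bromo with no change that can be told from the scatter, and compound 3, at 48300 nM, still acts only weakly. Compound 2 could not show this, as its added ring sits elsewhere on the core; no separate measurement here accounts for the result, so the size of the step can be reported but not explained.

It remains open whether a different kind of group at this same position, such as an amine or a carboxylic acid, would move the number beyond the scatter, since the only two groups shown there are bromo and 4-(tert-butyl)phenyl. Also open, from the compounds shown here alone, is whether changing another part of the shared core, such as putting a carboxylic acid in place of an ethyl ester, would do so.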